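The source may hold more compounds than are shown below. What is called first, only, known or untested is meant among the compounds shown, and "the series" means these compounds.

Notes on the series, two compounds measured so far. For the measured compounds named here, compound 1 `CCc1cccc(NC(=O)CN2CCN(c3ccc(Cl)cn3)CC2)c1` and compound 2 `O=C(CN1CCN(c2ccccn2)CC1)Nc1cncnc1` share a core and differ at two places, so no single structural step between them can be read. In an assay on HEK293 cells for displacement of a labelled ligand from D(4) dopamine receptor (Homo sapiens), read by scintillation counting, with a stated time of 60 min (on this read-out higher numbers stand for weaker inhibition and lower numbers for stronger inhibition), compound 1 gives 172 nM. In this assay compound 2 gives 39300 nM, the higher of the two numbers, with a gap to compound 1 that lies well beyond the scatter of repeated measurements. Compound 2 thus stands as the weaker of the two.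

The next compound to be measured is compound 3 `O=C(CN1CCN(c2ccc(Cl)cn2)CC1)Nc1cncnc1`. It differs from compound 2 in one place: chloro in place of hydrogen on an aromatic carbon, which also reads as pyridin-2-yl going to 5-chloropyridin-2-yl. Compound 1 already carries the 5-chloropyridin-2-yl group, but its amide part differs as well. The value of compound 1, 172 nM, cannot be attributed to the chloro alone.

For compound 3 a step toward a lower number than compound 2, of modest size and probably beyond the scatter, is expected a 4.9-fold lower number from compound 2 to compound 3 (0.69 log units; beyond the scatter). The estimate for compound 3 in this assay is 8000 nM, expected to fall between 2000 nM and 30000 nM.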

Compound 3, inhibition constant: > 50000 nM
Compound 3 gave a limit, no number; the forecaster's own chance of this, stated with the estimate: 5%; middle value at least 6.2-fold (0.79 log units) away from the limit.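

In this assay compound 3 gives > 50000 nM, a limit of the assay and not a number. From the compounds shown here alone, with pyrimidin-5-yl on the amide-type nitrogen, chloro in place of hydrogen on this aromatic carbon, two atoms from the ring nitrogen, brings no lower number: the result reads as an at least 1.2-fold higher number from compound 2 to compound 3 (0.10 log units; that floor lies within the scatter), so the true size and direction of the change beyond that floor remain unknown. With 5-chloropyridin-2-yl now held constant, pyrimidin-5-yl in place of 3-ethylphenyl can be read as a single change, and it gives an at least 290-fold higher number from compound 1 to compound 3 (2.46 log units; beyond the scatter), which places a large effect on the amide side, while both steps remain floors set by the same limit: the limit of > 50000 nM in this assay, at which 1 of the 3 values shown sits.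

Going by these compounds, the effect of the chloro when 3-ethylphenyl sits on the amide-type nitrogen stays open, as does the share of the large step that belongs to the ethyl group and the share that belongs to the aromatic ring itself. Also open, on these data alone, is how a methyl, a methoxy or an amine would read at the chloro position, and how a plain phenyl would read on the amide-type nitrogen.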